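A few compounds are considered here, and "the series" means these few. Any claim that something is new, unique, unknown or untested is made for them only; others in the source may bear on it.

Compound 1 `O=C(CSC(=S)N[C@H]1CCOC1=O)Nc1ccc(Br)cc1`: 28300 nM in a functional assay on SMMC-7721 cells (Homo sapiens) for cytotoxicity, read by MTT assay, with a stated time of 72 h; a higher number here means a weaker inhibitor, a lower number a stronger inhibitor.
Compound 2 `O=C(CSC(=S)N[C@H]1CCOC1=O)Nc1ccccc1`: in this assay compound 2 gives only a limit, > 128000 nM.
Compound 3 `O=C(CSC(=S)N[C@H]1CCOC1=O)Nc1cccc(C(F)(F)F)c1`: in this assay compound 3 also gives only a limit, > 128000 nM.

Compound 2 therefore stands at the limit, and so does one other of the three values (the limit of > 128000 nM in this assay, at which 2 of the 3 values shown sit). The step to compound 4 `O=C(CSC(=S)N[C@H]1CCOC1=O)Nc1ccc(O)cc1` is hydroxy in place of hydrogen on an aromatic carbon. Among the measured compounds shown here, of the measured steps, the one from compound 1 to compound 2 is an at least 4.5-fold higher number from compound 1 to compound 2 (0.65 log units; beyond the scatter), while the step from compound 2 to compound 3 is a step that the two limits leave unreadable from compound 2 to compound 3. Neither step starts from a readable number for compound 2, so no size can be carried over. For compound 4 the step of an at least 1.1-fold lower number from compound 2 to compound 4 (0.06 log units; that floor lies within the scatter) is expected to be none beyond the scatter, with the number most likely again at the limit. Compound 4 is estimated at 110000 nM, within 30000 nM to 300000 nM.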

Compound 4, half-maximal inhibitory concentration: > 128000 nM
Compound 4 ended at the assay's limit (the forecaster's own chance of this, stated with the estimate: 60%); at least 1.1-fold (0.06 log units) between middle value and limit.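

Hydroxy in place of bromo, para to a large group, gives an at least 4.5-fold higher number from compound 1 to compound 4 (0.65 log units; beyond the scatter), so a donor-bearing group at this position does not keep the readable number of compound 1 in this assay. Among the groups shown at this position, only bromo gives a readable number. The steps between compounds at the limit cannot be read, and compound 4 joins them: the limit of > 128000 nM in this assay, at which 3 of the 4 values shown sit.

Going by these compounds, whether chloro, iodo, methoxy or an amine at this position would also give a readable number remains open. So does how much lower than the limit any such number would fall.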